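The source may hold more compounds than are shown below. What is called first, only, known or untested is meant among the compounds shown, and "the series" means these compounds.

Measured so far in a functional assay on PC-3 cells (Homo sapiens) for inhibition, with a stated time of 72 h; on this read-out higher numbers stand for weaker inhibition and lower numbers for stronger inhibition:
- compound 1, `O=C(Nc1ccccc1)Nc1nc(Sc2c[nH]c3ccccc23)cc(N2CCCC2)n1`: 14900 nM
- compound 2, `COc1ccc(NC(=O)Nc2nc(Nc3cc(OC)cc(OC)c3)cc(Sc3c[nH]c4ccccc34)n2)cc1`: 15100 nM

Of the two numbers shown, the one for compound 2 is nominally the larger, but its difference from compound 1 lies within the usual scatter, so on this assay the two compounds cannot be told apart; neither counts as the weaker or the stronger.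

Compound 3, `COc1ccc(NC(=O)Nc2nc(Sc3c[nH]c4ccccc34)cc(N3CCCC3)n2)cc1`, is not yet measured. It differs from compound 2 in one place: pyrrolidin-1-yl in place of (3,5-dimethoxyphenyl)amino on an aromatic carbon. With this change, compound 3 shares its pyrrolidin-1-yl group with compound 1 and its ((4-methoxyphenyl)carbamoyl)amino group with compound 2. Among the measured compounds shown here, both measured compounds give numbers within the scatter of each other, so there is no measured step on which a direction could rest, and the change is expected to bring no step beyond the scatter in this assay. The expected step is a 1.1-fold lower number from compound 2 to compound 3 (0.03 log units; within the scatter). For compound 3 the estimate in this assay is 14000 nM, with a range from 5000 nM to 40000 nM.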

Compound 3, half-maximal inhibitory concentration: 21500 nM
Estimate against measurement, compound 3: 1.5-fold (0.19 log units) below, within the range that was stated.
By their numbers in this assay, from the lowest: compounds 1, 2 and 3 (each within the scatter of the next).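

In this assay, pyrrolidin-1-yl in place of (3,5-dimethoxyphenyl)amino on the aromatic carbon next to the ring nitrogen gives a 1.4-fold higher number from compound 2 to compound 3 (0.15 log units; within the scatter), so this position holds either a group of 11 heavy atoms with an aromatic ring or one of 5 heavy atoms with a non-aromatic ring, and the read-out does not separate the two. Among the compounds shown here, the second single change, methoxy in place of hydrogen on an aromatic carbon, gives a 1.4-fold higher number from compound 1 to compound 3 (0.16 log units; within the scatter), so the methoxy group on the phenyl of the urea also produces no step that can be told from scatter in this pair. Nothing measured in the series bears on the reason for these numbers.

Going by these compounds, all three compounds lie within the scatter of their neighbours, so it remains open whether any group at this carbon can move the read-out beyond the scatter, for instance a morpholin-4-yl group, a dimethylamino group or a carboxylic acid. On these data alone, the (1H-indol-3-yl)sulfanyl group is common to all three compounds, so its contribution to the numbers in this assay also remains open, as would be tested by an aniline-type amino group or a phenylsulfanyl group in its place.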